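This account rests on a few compounds, and the source may have more. Where it says the series, first, only, none or still open, it means among the compounds named here.

Measured in a functional assay on K562 cells (Homo sapiens) for cytotoxicity, read by MTT assay, with a stated time of 48 h; on this read-out higher numbers stand for weaker inhibition and lower numbers for stronger inhibition:
- compound 1 `COc1cc([C@@H]2C[C@]2(CO)C(=O)Nc2ccccc2Cl)cc(OC)c1OC`: 16900 nM
- compound 2 `COc1cc([C@H]2C[C@]2(CO)C(=O)Nc2ccccc2Cl)cc(OC)c1OC`: > 100000 nM, a limit
- compound 3 `CCOC(=O)[C@@]1(C(=O)Nc2ccccc2Cl)C[C@H]1c1cc(OC)c(OC)c(OC)c1`: > 100000 nM, a limit

Compound 3 gives > 100000 nM, which is a limit and not a number. It therefore has no exact position in the series, and the same applies to compound 2, as shown by the limit of > 100000 nM in this assay, at which 2 of the 3 values shown sit.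

The next compound is compound 4 `COc1cc([C@@H]2C[C@@]2(CO)C(=O)Nc2ccccc2Cl)cc(OC)c1OC`. Relative to compound 3, the change is hydroxymethyl in place of ethoxycarbonyl on a saturated ring carbon. In words, hydroxymethyl stands in place of ethoxycarbonyl on a saturated ring carbon.

Among the compounds with values here, no measured step covers this exchange directly. Within the data shown here, the only measured step is an at least 5.9-fold higher number from compound 1 to compound 2 (0.77 log units; beyond the scatter), and it bears on the exchange only indirectly. Both of its compounds carry hydroxymethyl, and the step goes with the fact that compounds 1 and 2 differ only in the configuration as drawn. Hydroxymethyl therefore does not by itself ensure a measurable value, since compound 2 goes against any such pattern. Compound 1 still shows that a hydroxymethyl compound can give a number, at 16900 nM.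

A modest move toward a lower number in this assay is expected, though a result that remains at the limit is about as likely. The estimated shift is an at least 2.0-fold lower number from compound 3 to compound 4 (0.30 log units; that floor lies within the scatter). The expected value for compound 4 is 50000 nM, with an estimated range from 12000 nM to 150000 nM.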

Compound 4, half-maximal inhibitory concentration: 18400 nM
For compound 4 the middle estimate is 2.7-fold (0.43 log units) above the measured one; the range from low to high includes it.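

In this assay, within the data shown here, hydroxymethyl in place of ethoxycarbonyl on a saturated ring carbon of the three-membered ring gives an at least 5.4-fold lower number from compound 3 to compound 4 (0.73 log units; beyond the scatter); this is a floor set by a limit, and it is the first measured reading of this exchange. Inverting both stereocentres gives an at least 5.4-fold lower number from compound 2 to compound 4 (0.73 log units; beyond the scatter), whereas inverting one stereocentre gives a 1.1-fold higher number from compound 1 to compound 4 (0.04 log units; within the scatter), so two hydroxymethyl stereoisomers now give numbers that lie within the scatter of each other, while a third stays at a limit. Hydroxymethyl therefore does not ensure a measurable value, with compound 2 going against any such pattern, and the gap in this mirror-image pair goes with configuration alone: the fact that compounds 2 and 4 differ only in the configuration as drawn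

Compound 3 is the only ethoxycarbonyl compound shown, so it remains open whether that group would give a number in another configuration, and the exchange cannot yet be separated from configuration across the full stereoisomer set. On these data alone, it is also open how a carboxylic acid, an aminomethyl group or a longer hydroxyalkyl chain at this ring carbon would read out in this assay, in either the configuration of compound 1 or that of compound 4.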